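A few compounds are considered here, and "the series" means these few. Any claim that something is new, unique, unknown or untested is made for them only; others in the source may bear on it.

Measured so far in an ADME assay on PBMC cells (Homo sapiens) for cytotoxicity, with a stated time of 5 days; on this read-out lower numbers stand for stronger inhibition and higher numbers for weaker inhibition:
- compound 1 `CC(C)(CO)Nc1nc(N)nc2c1ncn2[C@H]1C[C@H](N=[N+]=[N-])[C@@H](CO)O1`: > 100000 nM
- compound 2 `C=CCNc1ncnc2c1ncn2[C@H]1C[C@H](N=[N+]=[N-])[C@@H](CO)O1`: 51100 nM
- compound 3 `C=CCNc1nc(N)nc2c1ncn2[C@H]1C[C@H](N=[N+]=[N-])[C@@H](CO)O1`: > 100000 nM

Compound 3 gives > 100000 nM, which is a limit of the assay and not a number. Compound 1 also gives a limit, > 100000 nM, so these two compounds make up (the limit of > 100000 nM in this assay, at which 2 of the 3 values shown sit).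

Compound 4 `[N-]=[N+]=N[C@H]1C[C@H](n2cnc3c(NCCCCCO)nc(N)nc32)O[C@@H]1CO` differs from compound 3 by 4-hydroxybutyl in place of vinyl on a saturated chain carbon bound to a nitrogen on an aromatic ring. In other words, allyl becomes 5-hydroxypentyl.

Among the compounds with values here, two measured steps bear on this change. The closer one also changes the group on that nitrogen, but it gives a step that the two limits leave unreadable from compound 1 to compound 3. The other, an at least 1.9-fold higher number from compound 2 to compound 3 (0.29 log units; that floor lies within the scatter), changes a different place and gives no readable size for this change. Neither step therefore points to a real change in this assay, and no step beyond the scatter is expected. The expected result is a number no higher from compound 3 to compound 4 (the limit leaves the size open). Compound 4 is most likely to reach the same limit as compound 3. As a value, the estimate for compound 4 is 100000 nM, with an expected range from 40000 nM to 150000 nM.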

Compound 4, half-maximal inhibitory concentration: > 100000 nM
Compound 4: only a limit was reported; the forecaster's own chance of this, stated with the estimate: 75%; the middle value sits exactly at the limit.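

The steps to compound 4 from compound 1 and from compound 3 cannot be read, because all three compounds stop at the same limit and give no number: the limit of > 100000 nM in this assay, at which 3 of the 4 values shown sit.

The compounds shown leave open whether allyl, 5-hydroxypentyl and 1-(hydroxymethyl)-1-methylethyl on that nitrogen differ at all in this assay.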